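Adding a Hydroxy Group to the Oxalamide Phenyl Ring

This account rests on a few compounds, and the source may have more. Where it says the series, first, only, none or still open, it means among the compounds named here.

Of the compounds shown here, two built on a shared core have been measured in a functional assay on cells (T-cell, Mus musculus) for inhibition; on this read-out lower numbers stand for stronger inhibition and higher numbers for weaker inhibition. Compound 1, `O=C(Nc1ccc(I)cc1)Nc1ccc2c(c1)COC2=O`, links the core through a urea to a ring bearing iodine, and in this assay compound 1 gives 1370 nM. Compound 2, `O=C(Nc1ccccc1)C(=O)Nc1ccc2c(c1)COC2=O`, instead joins the core through an oxalamide to a plain phenyl ring; in this assay compound 2 gives 36100 nM. Of these two numbers compound 2 stands highest, so it is the weaker inhibitor of the pair, and its gap to compound 1 lies well beyond the usual scatter. The two compounds differ in both the linker and the ring, so this pair says nothing about either change on its own.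

Compound 3, `O=C(Nc1ccc(O)cc1)C(=O)Nc1ccc2c(c1)COC2=O`, keeps the oxalamide of compound 2 and differs from it in one place: hydroxy in place of hydrogen on an aromatic carbon. Among the compounds with values here, no measured pair shows this change, so its effect is uncertain. The expected step is a 2.0-fold lower number from compound 2 to compound 3 (0.30 log units; within the scatter), small and toward stronger inhibition, at about the edge of the scatter. Compound 3 is estimated at 18000 nM, with a likely range from 5000 nM to 60000 nM.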

Compound 3, half-maximal inhibitory concentration: 5030 nM
Beside the measured number, compound 3's estimate is 3.6-fold (0.55 log units) above it; low and high end bracket the measured number.
By their numbers in this assay, from the lowest: compound 1; then compound 3; then compound 2.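

In this assay the change from phenyl to 4-hydroxyphenyl gives a 7.2-fold lower number from compound 2 to compound 3 (0.86 log units; beyond the scatter) and so shows that this place on the ring of the oxalamide series responds to a substituent, with a single added oxygen atom enough to move the number past the usual scatter. Within the data shown here, until now the only comparison changed the linker and the ring together, so nothing could be tied to the ring alone; here the linker and the shared core stay fixed, and the shift belongs to the hydroxy group by itself. No measurement at hand explains why this one group shifts the number as it does.

The compounds shown leave open whether a hydroxy group is specifically needed here, or whether a methoxy group, an amine or a carboxylic acid at the same place would give a similar, larger or smaller step. They also leave open whether the same change would carry over to the urea linker of compound 1, and how other places on this ring would respond.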